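The compounds below may be only part of what the source reports. "The series", "measured", "known", "first", "only" and "open" are said of these compounds alone.

Measured in a functional assay on MCF7 cells (Homo sapiens) for cytotoxicity, read by MTT assay, with a stated time of 96 h; on this read-out lower numbers stand for stronger inhibition and higher numbers for weaker inhibition:
- Compound 1 `COc1cc(C(=O)c2cn(-c3cccc(C)c3)cc2-c2ccccc2[N+](=O)[O-])cc(OC)c1OC`: 220 nM
- Compound 2 `COc1cc(C(=O)c2cn(-c3cccc(C)c3)cc2-c2cccc(N)c2)cc(OC)c1OC`: 130 nM
- Compound 3 `COc1cc(C(=O)c2cn(-c3cccc(C)c3)cc2-c2ccc(N)cc2)cc(OC)c1OC`: 18 nM

Compound 1 stands level with compound 2, as a 1.7-fold lower number from compound 1 to compound 2 (0.23 log units; within the scatter) shows, and well above compound 3.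

The next compound, compound 4 `COc1cc(C(=O)c2cn(-c3ccc(N)cc3)cc2-c2ccccc2[N+](=O)[O-])cc(OC)c1OC`, keeps the 2-nitrophenyl group of compound 1 and changes a different place: 4-aminophenyl in place of 3-methylphenyl on an aromatic nitrogen. In words, 4-aminophenyl comes in place of 3-methylphenyl on an aromatic nitrogen.

Among the compounds with values here, no measured step touches this place. The nearest evidence has the same 4-aminophenyl group entering on an aromatic carbon instead: a 12-fold lower number from compound 1 to compound 3 (1.09 log units; beyond the scatter), and a 7.2-fold lower number from compound 2 to compound 3 (0.86 log units; beyond the scatter). Those steps sit at another position, so they are only a weak guide. A smaller step in the same direction is therefore expected in this assay, and it may not pass the scatter at all.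

The estimated step is a 2.2-fold lower number from compound 1 to compound 4 (0.34 log units; beyond the scatter). For compound 4 the expected value is 100 nM, estimated to lie between 25 nM and 400 nM.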

Compound 4, half-maximal inhibitory concentration: 53 nM
Estimate against measurement, compound 4: 1.9-fold (0.28 log units) above; the measured number falls inside the stated range.
By their numbers in this assay, from the lowest: compound 3; then compound 4; then compounds 2 and 1 (each within the scatter of the next).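

Within the data shown here, the aromatic nitrogen is a place where the number in this assay can change, not only the aromatic carbon varied in the earlier compounds: 4-aminophenyl in place of 3-methylphenyl gives a 4.2-fold lower number from compound 1 to compound 4 (0.62 log units; beyond the scatter). The group that enters has the same count of heavy atoms as the one that leaves and also a six-membered aromatic ring of carbon only, so a change that keeps both of these still moves the number beyond the scatter. No measurement shown here explains why the number falls.

This single step changes both the substituent on the phenyl ring and where it sits, so it cannot tell the amine from its placement. 3-Aminophenyl and 4-methylphenyl on the aromatic nitrogen would separate those two changes, and a hydroxyl or methoxy group in the amine's place would test whether an amine is needed at all.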